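The compounds below may be only part of what the source reports. "The series", "measured", "known", "first", "only" and "open" are said of these compounds alone.

Compound 1 (`Cc1ccc(C2(c3ccc(O)cc3)C(=O)Nc3c2ccc(F)c3F)cc1`) gives 1.7 nM in a functional assay on MCF7 cells (Homo sapiens) for cytotoxicity, read by WST assay, with a stated time of 72 h (on this read-out higher numbers stand for weaker inhibition and lower numbers for stronger inhibition), as the lower of the two compounds with a single number. Compound 2 (`O=C1Nc2c(ccc(F)c2F)C1(c1ccncc1)c1ccc(O)cc1`) gives 37 nM as the higher of those two, and the gap is a 22-fold higher number from compound 1 to compound 2 (1.34 log units; beyond the scatter) in this series. Compound 3 (`O=C1Nc2c(ccc(F)c2F)C1(c1ccc(O)cc1)C1CCCCC1`), with a six-membered non-aromatic ring of carbon only on the same saturated ring carbon, gives 13 nM; 18 nM; > 1000 nM (3 entries) as its entries, which do not come to a single number, and it is the closest guide to what follows.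

The next structure is compound 4 (`O=C1Nc2c(ccc(F)c2F)C1(CC1CCCCC1)c1ccc(O)cc1`), and the change from compound 2 is cyclohexylmethyl in place of pyridin-4-yl on a saturated ring carbon in full: cyclohexylmethyl in place of pyridin-4-yl. Among the measured compounds shown here, only one measured step bears directly on this position, and it shows that a swap here can matter. A modest change in this assay is expected, probably toward a lower number, with a wide margin because a 22-fold higher number from compound 1 to compound 2 (1.34 log units; beyond the scatter) was so large.

The estimated change is a 1.5-fold lower number from compound 2 to compound 4 (0.17 log units; within the scatter) in this expectation. Compound 4 is expected at about 25 nM with an estimated range from 4 nM to 200 nM in this assay's terms.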

Compound 4, half-maximal inhibitory concentration: 102 nM
Compound 4: the middle estimate sits 4.1-fold (0.61 log units) below what was measured, and the stated range covers the measured number.
By their numbers in this assay, from the lowest: compound 1; then compound 2; then compound 4.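

In this assay, among the compounds shown here, the first non-aromatic group with a methylene link at this saturated ring carbon gives a higher number than either aromatic ring, with a 2.8-fold higher number from compound 2 to compound 4 (0.44 log units; beyond the scatter) and a 60-fold higher number from compound 1 to compound 4 (1.78 log units; beyond the scatter). Removing the ring nitrogen of pyridin-4-yl therefore does not by itself lead back toward the low number of compound 1, whose 4-methylphenyl group also has only carbon in its ring; in these compounds, what enters matters as well as what leaves. The effect of the linking carbon alone cannot be read against compound 3, because its entries do not come to one number and the last of them is a limit of the assay: the several entries of compound 3 in this assay, 13 nM; 18 nM; > 1000 nM (3 entries).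

As far as these compounds go, it remains open how an open chain such as n-hexyl would compare with the cyclohexylmethyl group at this carbon. The same holds for a ring bearing an amine or a carboxylic acid.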